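The source may hold more compounds than are shown below. What is called first, only, known or untested is meant among the compounds shown, and "the series" means these compounds.

The measured compounds in a functional assay on WM1361 cells (Homo sapiens) for inhibition, read by MTT assay, with a stated time of 24 h; on this read-out lower numbers stand for stronger inhibition and higher numbers for weaker inhibition:

compound 1, `CCN1CCN(c2c(CO)c(=O)oc3ccccc23)CC1`, a limit of the assay: > 100000 nM
compound 2, `O=c1oc2ccccc2c(N2CCN(c3ccc(F)cc3)CC2)c1CO`, a limit of the assay: > 50000 nM
compound 3, `O=c1oc2ccccc2c(N2CCN(c3cccc(C(F)(F)F)c3)CC2)c1CO`, a limit of the assay: > 50000 nM

Compound 1 therefore stands only at a limit in this assay, with no number of its own. Going by the values given here, the two further values shown are limits as well, so no compound among the three is placed against another. Among the compounds with values here, the one step that pairs two of them, a step that the two limits leave unreadable from compound 1 to compound 2, connects two limits and cannot be read in size or direction; the evidence for this rests on the limit of > 100000 nM in this assay, at which 1 of the 3 values shown sits, and on (the limit of > 50000 nM in this assay, at which 2 of the 3 values shown sit).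

Compound 4, `O=c1oc2ccccc2c(N2CCN(c3ccccc3F)CC2)c1CO`, differs from compound 1 by 2-fluorophenyl in place of ethyl on an amine nitrogen in a ring. The nearest measured step, from compound 1 to compound 2, swaps the same ethyl for an aryl group on the same ring nitrogen, and its size is unreadable, so nothing in the data points to a change in this assay beyond the scatter in either direction. With all three values at limits, the expectation is that compound 4 likewise returns no number in this assay.

On that basis compound 4 is estimated at 80000 nM, in a range from 25000 nM to 250000 nM, which is expected to mean a step of an at least 1.2-fold lower number from compound 1 to compound 4 (0.09 log units; that floor lies within the scatter).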

Compound 4, half-maximal inhibitory concentration: > 50000 nM
Compound 4 was reported as a limit; the forecaster's own chance of this, stated with the estimate: 85%; the middle value lies beyond the limit too.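

In this assay compound 4 gives > 50000 nM, which is a limit of the assay and not a number. Its steps from compound 1 and from compound 2 therefore cannot be read in size or direction: the limit of > 50000 nM in this assay, at which 3 of the 4 values shown sit. The compounds shown leave open whether any group on the amine nitrogen in the ring gives a measurable value in this assay.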